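Cytotoxicity notes on a benzyloxy-pyrimidine aniline series

The source may report more compounds than this note shows. Statements on the series, on what has been measured and on what is new or still open speak of the compounds shown alone.

Measured compounds so far:
- compound 1 `N#Cc1ccc(Nc2nccc(OCc3ccc(Cl)cc3)n2)cc1` — 156000 nM
- compound 2 `N#Cc1ccc(Nc2nccc(OCc3ccccc3F)n2)cc1` — 151000 nM
- compound 3 `N#Cc1ccc(Nc2nccc(OCc3ccccc3C#N)n2)cc1` — 113000 nM

All three were read in an ADME assay on MT4 cells (Homo sapiens) for cytotoxicity, read by MTT assay, with a stated time of 5 days; on this read-out higher numbers stand for lower toxicity in this test and lower numbers for higher toxicity in this test. Compound 1 carries the highest of the three numbers, but its nearest neighbour, compound 2, sits within the scatter of it, as does compound 3: the steps of a 1.0-fold lower number from compound 1 to compound 2 (0.01 log units; within the scatter) and a 1.4-fold lower number from compound 1 to compound 3 (0.14 log units; within the scatter) are both within the scatter, and so is a 1.3-fold lower number from compound 2 to compound 3 (0.13 log units; within the scatter). Among the measured compounds shown here, on these numbers no compound can be called more or less toxic than another.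

Compound 4 `N#Cc1ccc(COc2ccnc(Nc3ccc(C#N)cc3)n2)cc1` is not yet measured. It differs from compound 1 by cyano in place of chloro on an aromatic carbon, which, cut one bond further out, reads 4-chlorophenyl to 4-cyanophenyl. The measured steps that bear on this are those that exchange the substituent on the same benzyl ring, namely a 1.0-fold lower number from compound 1 to compound 2 (0.01 log units; within the scatter) and a 1.4-fold lower number from compound 1 to compound 3 (0.14 log units; within the scatter), and the cyano-for-fluoro exchange a 1.3-fold lower number from compound 2 to compound 3 (0.13 log units; within the scatter); none of them moved the number beyond the scatter. The step to compound 4 is therefore expected to be a 1.1-fold lower number from compound 1 to compound 4 (0.05 log units; within the scatter), that is, no change beyond the scatter in this assay. For compound 4 the estimate is 140000 nM, with a range from 70000 nM to 280000 nM.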

Compound 4, half-maximal cytotoxic concentration: 209000 nM
Compound 4: the middle estimate sits 1.5-fold (0.17 log units) below what was measured, within the range that was stated.
By their numbers in this assay, from the lowest: compounds 3, 2, 1 and 4 (each within the scatter of the next).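

Cyano can stand in place of chloro at this place, para to a large group, with no shift beyond the scatter in this assay: the step is a 1.3-fold higher number from compound 1 to compound 4 (0.13 log units; within the scatter), so a group that adds a hydrogen-bond acceptor leaves the read-out where chloro had it. Among the compounds shown here, compound 4 also gives the first direct comparison of where the cyano group sits on this ring, and even this change, at a 1.8-fold higher number from compound 3 to compound 4 (0.27 log units; within the scatter), stays within the scatter despite being the largest step yet seen; the change from 2-fluorophenyl to 4-cyanophenyl, at a 1.4-fold higher number from compound 2 to compound 4 (0.14 log units; within the scatter), is likewise within it. No supporting measurement is available to account for any of these steps.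

The compounds shown cover only chloro, fluoro and cyano on this ring, so whether an amine or a carboxylic acid here would move the number beyond the scatter remains open. Also open, on these data alone, is whether a longer chain between the oxygen and this ring would leave the read-out as unchanged as these ring exchanges did.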